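The source may hold more compounds than are shown below. What is called first, only, known or untested is meant among the compounds shown, and "the series" means these compounds.

Among the measured compounds shown here, compound 1 `O=C1C(=O)N(CCCCn2cc(COc3cc(=O)oc4ccccc34)nn2)c2ccc(F)cc21` is one of three compounds measured in a functional assay on THP-1 cells (Homo sapiens) for inhibition, read by sulforhodamine B assay, with a stated time of 48 h, tested at 50 uM; a lower number here means less inhibition of growth, a higher number more inhibition of growth at the concentration tested; in this assay compound 1 gives 77%. Compound 2 `O=C1C(=O)N(CCCn2cc(COc3cc(=O)oc4ccccc34)nn2)c2ccc(F)cc21` gives 86% in this assay, a value within the scatter of compound 1. Compound 3 `O=C1C(=O)N(CCCCCn2cc(COc3cc(=O)oc4ccccc34)nn2)c2ccc(Br)cc21` gives 52% in this assay, a lower number beyond the scatter, so compound 1 stands second highest of the three. Compound 4 `COc1ccc2c(c1)C(=O)C(=O)N2CCCCn1cc(COc2cc(=O)oc3ccccc23)nn1` has not yet been measured. It differs from compound 1 in one place: methoxy in place of fluoro on an aromatic carbon. For the measured compounds named here, no measured pair shows what a methoxy in place of a fluoro does, so in this assay the expected step is a modest decrease, perhaps no larger than the scatter. Compound 4 is expected to give 68%, in the range 50% to 85%. The estimated step of a number 9 percentage points lower from compound 1 to compound 4 (within the scatter) is expected to be small.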

Compound 4, percent growth inhibition at one concentration: 52%
The estimate for compound 4 lay 16 percentage points above the measured number; the range from low to high includes it.
By their numbers in this assay, from the lowest: compounds 3 and 4 (each within the scatter of the next); then compounds 1 and 2 (each within the scatter of the next).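

In this assay, among the compounds shown here, methoxy in place of fluoro on this aromatic carbon gives a number 25 percentage points lower from compound 1 to compound 4 (beyond the scatter) and so gives the first direct sign that the group at this position matters, since the earlier compounds differ from one another in more than one place. For the compounds shown here, the single pair cannot separate the loss of fluoro from the gain of methoxy. Nothing available explains the step.

Still open, on these data alone, is how an amine or a carboxylic acid would fare on this carbon. As far as these compounds go, whether methoxy brings a similar step on a longer chain also remains unknown.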